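From 3-methoxyphenyl to 4-methylphenyl at the assay limit

This account rests on a few compounds, and the source may have more. Where it says the series, first, only, none or still open, it means among the compounds named here.

Compound 1 `COc1ccc(-c2nc3c(c(C)nn3-c3ccccc3)c(-c3ccccc3O)c2C#N)cc1`, compound 2 `COc1cccc(-c2nc3c(c(C)nn3-c3ccccc3)c(-c3ccccc3O)c2C#N)c1` and compound 3 `CCc1ccc(-c2nc3c(c(C)nn3-c3ccccc3)c(-c3cccc(O)c3)c2C#N)cc1` have all been run in an ADME assay on BJ cells (Homo sapiens) for cytotoxicity, with a stated time of 72 h; a higher number here means that more compound is needed for the effect, a lower number that less compound is needed. Compound 1 gives > 23000 nM, which is a limit and not a number. Compound 2 gives > 23000 nM, also a limit. Compound 3 gives > 20000 nM, again a limit. Compound 2 therefore has no exact position in the series: it shares (the limit of > 23000 nM in this assay, at which 2 of the 3 values shown sit). Compound 3 alone stands at the limit of > 20000 nM in this assay, at which 1 of the 3 values shown sits.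

Compound 4 `Cc1ccc(-c2nc3c(c(C)nn3-c3ccccc3)c(-c3ccccc3O)c2C#N)cc1` has not yet been measured. Relative to compound 2 it carries 4-methylphenyl in place of 3-methoxyphenyl on an aromatic carbon. The change is 4-methylphenyl in place of 3-methoxyphenyl on an aromatic carbon, next to the ring nitrogen and ortho to a cyano group.

Going by the values given here, the only measured step that bears on this place is a step that the two limits leave unreadable from compound 1 to compound 2. It offers no size to carry over. The working expectation rests on compound 2, whose limit is > 23000 nM. No step beyond the scatter is expected in this assay, and no direction can be assigned. The expected step is a number no higher from compound 2 to compound 4 (the limit leaves the size open). For compound 4 the estimate is 23000 nM, with an expected range of 10000 nM to 40000 nM.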

Compound 4, half-maximal effective concentration: 22200 nM
For compound 4 the middle estimate is 1.0-fold (0.02 log units) above the measured one; the measured number falls inside the stated range.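

In this assay, going by these compounds alone, compound 4 gives 22200 nM, the first exact number for a group on this aromatic carbon, next to the ring nitrogen and ortho to a cyano group. The two changes can now be set against a number on one side: an at least 1.0-fold lower number from compound 2 to compound 4 (0.01 log units; that floor lies within the scatter) for 4-methylphenyl in place of 3-methoxyphenyl, and an at least 1.0-fold lower number from compound 1 to compound 4 (0.01 log units; that floor lies within the scatter) for methyl in place of methoxy. Compound 2 remains a limit and not a number, so neither step has a known full size, only a floor: the limit of > 23000 nM in this assay, at which 2 of the 4 values shown sit.

Whether the cytotoxicity read-out at this position responds to anything other than the methyl and methoxy aryl groups shown remains open, for instance to a 4-aminophenyl group, a 4-carboxyphenyl group or a phenyl ring bearing a longer chain such as butyl. Also open, going by these compounds, is whether compound 1 and compound 2 sit close to compound 4 or far from it, since only exact numbers for those two compounds could settle the size of the steps.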